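A few compounds are considered here, and "the series" means these few. Any claim that something is new, unique, unknown or untested is made for them only; others in the source may bear on it.

The series rests on a shared core, seen in compound 1, `CCNC(=O)CC1CCc2cc(OC)c(OC)cc21`, which carries a single ethyl group and a hydrogen on its amide-type nitrogen. In a functional assay on the whole organism (strain Wistar) for inhibition, with Rattus norvegicus as the target, read by paw edema, with stated times of 60 min and 1 h, at a dose of 100 mg/kg by the oral route (a higher number here means more inhibition at the dose given (going by the name of the read-out), a lower number less inhibition), compound 1 gives 15.6%. Compound 2, `CCN(CC)C(=O)CC1CCc2cc(OC)c(OC)cc21`, has that hydrogen replaced, and in this assay compound 2 gives 31.3%; the step of a number 15.7 percentage points higher from compound 1 to compound 2 (beyond the scatter) is the result. Compound 3, `COc1cc2c(cc1OC)C(CC(=O)NC(C)C)CC2`, instead bears an isopropyl group on the nitrogen, and in this assay compound 3 gives 31.3%. The step of a number 15.7 percentage points higher from compound 1 to compound 3 (beyond the scatter) and the step of no change at the digits printed from compound 2 to compound 3 (within the scatter) fix its place: level with compound 2, the two together giving the highest of the three numbers.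

Compound 4, `CCCCCNC(=O)CC1CCc2cc(OC)c(OC)cc21`, differs from compound 3 in one place: pentyl in place of isopropyl on an amide-type nitrogen. Going by the values given here, no measured step swaps one alkyl chain on the nitrogen for a longer one. The nearest guide is no change at the digits printed from compound 2 to compound 3 (within the scatter), where two rather different carbon groupings on the nitrogen gave the same number, while a number 15.7 percentage points higher from compound 1 to compound 2 (beyond the scatter) and a number 15.7 percentage points higher from compound 1 to compound 3 (beyond the scatter) show that adding carbon there, rather than rearranging it, raised the number modestly. The expected step in this assay is therefore none beyond the scatter, a number 0.3 percentage points lower from compound 3 to compound 4 (within the scatter). Compound 4 is estimated to give about 31%, within a range of 16% to 46%.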

Compound 4, a percentage reported as inhibition, in the whole organism at one dose (the size of the read-out at that dose, not a potency): 34.4%
For compound 4 the middle estimate is 3.4 percentage points below the measured one; the range from low to high includes it.
By their numbers in this assay, from the lowest: compound 1; then compounds 2, 3 and 4 (each within the scatter of the next).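

In this assay, going by these compounds alone, pentyl in place of isopropyl on the amide-type nitrogen gives a number 3.1 percentage points higher from compound 3 to compound 4 (within the scatter), so this position accepts a longer chain of 5 carbons with no step that stands out from the scatter. Pentylamino in place of diethylamino on the carbonyl carbon reads the same way, with a number 3.1 percentage points higher from compound 2 to compound 4 (within the scatter), so one longer chain on the nitrogen and two short ones cannot be told apart here. The separation from the ethyl compound holds for this new group too, with a number 18.8 percentage points higher from compound 1 to compound 4 (beyond the scatter), but among compound 2, compound 3 and compound 4 the number does not follow the size of the group.

Nothing measured here on these compounds explains why the numbers fall as they do. From the compounds shown here alone, it remains open whether a still longer chain such as octyl, or a chain ending in an amine or a carboxylic acid, would hold the number on this nitrogen, and a reading at one dose gives the size of the effect there, not a potency.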